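A hydroxycyclopentyl group replaces 1-hydroxy-1-phenylethyl

A few compounds are considered here, and "the series" means these few. Any claim that something is new, unique, unknown or untested is made for them only; others in the source may bear on it.

Within the data shown here, in an ADME assay on HepG2 cells (Homo sapiens) for cytotoxicity, read by MTT assay, with a stated time of 72 h (a lower number here means that less compound is tolerated, a higher number that more compound is tolerated), compound 2 `CC(O)(C#Cc1cc(Cl)cn2c([N+](=O)[O-])c(CS(=O)(=O)c3ccccc3)nc12)c1ccccc1` gives 18800 nM as the only actual number so far. In this assay compound 1 `O=[N+]([O-])c1c(CS(=O)(=O)c2ccccc2)nc2c(C#Cc3cccc(F)c3)cc(Cl)cn12` gives only a limit (> 3900 nM). Compound 3 `O=[N+]([O-])c1c(CS(=O)(=O)c2ccccc2)nc2c(C#CC3(O)CCCC3)cc(Cl)cn12` carries 1-hydroxycyclopentyl in place of the 1-hydroxy-1-phenylethyl of compound 2 on a triple-bonded carbon (1-hydroxycyclopentyl in place of 1-hydroxy-1-phenylethyl on a triple-bonded carbon). A six-membered aromatic ring of carbon only thus gives way to a five-membered non-aromatic ring of carbon only, while the hydrogen-bond donor and acceptor counts stay the same. Among the measured compounds shown here, the one measured step at this place (a step that the limit leaves unreadable from compound 1 to compound 2) offers no size to carry over. With compound 2 at 18800 nM as the only anchor, no step beyond the scatter is expected in this assay for this change. The estimated step (a 1.0-fold lower number from compound 2 to compound 3 (0.02 log units; within the scatter)) is accordingly small. Compound 3 is expected at 18000 nM (estimated range 8000 nM to 40000 nM).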

Compound 3, half-maximal cytotoxic concentration: > 31300 nM
Compound 3 was reported as a limit; the forecaster's own chance of this, stated with the estimate: 30%; at least 1.7-fold (0.24 log units) between middle value and limit.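

In this assay, compound 3 gives only a limit, so no exact value stands for it: the limit of > 31300 nM in this assay, at which 1 of the 3 values shown sits.

Even so, this is the first step at this position with a readable size, though only as a floor: 1-hydroxycyclopentyl in place of 1-hydroxy-1-phenylethyl on a triple-bonded carbon gives an at least 1.6-fold higher number from compound 2 to compound 3 (0.22 log units; that floor lies within the scatter). The change therefore shows no fall in the number, while the floor alone does not establish a rise beyond the scatter, and the steps from compound 1 cannot be read.

From the compounds shown here alone, whether the true value of compound 3 stands clear of compound 2 remains open. So does how an amine or an open-chain group such as 2-hydroxypropan-2-yl would read on the same triple-bonded carbon in this assay.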